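The source may report more compounds than this note shows. Statements on the series, on what has been measured and on what is new or still open speak of the compounds shown alone.

Three compounds have so far been measured in a functional assay on C6 cells (Rattus norvegicus) for cytotoxicity, read by MTT assay, with a stated time of 24 h, tested at 50 ug/mL; on this read-out higher numbers stand for a weaker effect at the one concentration tested and lower numbers for a stronger effect:

compound 1, `O=C(CSc1nnnn1-c1ccccc1)N/N=c1/scc(-c2ccc(F)cc2)n1-c1ccccc1`, giving 43.7%
compound 2, `O=C(CSc1ncccn1)N/N=c1/scc(-c2ccc(Br)cc2)n1-c1ccccc1`, giving 69%
compound 3, `Cc1ccc(-c2cs/c(=N/NC(=O)CSc3ncccn3)n2-c2ccccc2)cc1`, giving 64.4%

On these numbers compound 3 stands second highest of the three. Among the measured compounds shown here, its nearest neighbour is compound 2, and the only single-point step among the measured compounds, a number 4.6 percentage points lower from compound 2 to compound 3 (within the scatter), is within the scatter. For the measured compounds named here, the furthest is compound 1, whose number lies beyond the scatter below that of compound 3; but compound 1 and compound 3 differ in more than one place, so no step is counted between them.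

Compound 4 is `O=C(CSc1ncccn1)N/N=c1/scc(-c2ccc(F)cc2)n1-c1ccccc1`. Compared with compound 3 the change is fluoro in place of methyl on an aromatic carbon.

Going by the values given here, the one step that bears on this is the change from compound 2 to compound 3, which shows that exchanging one small group for another at that place on the ring left the read-out in this assay unchanged within the scatter. Compound 1 also carries fluoro on that ring but has a different sulfur-linked heteroaryl, so its lower number cannot be assigned to the fluoro alone. The step expected in this assay is therefore a number 2.4 percentage points lower from compound 3 to compound 4 (within the scatter), that is, none beyond the scatter. Compound 4 is estimated at 62%, between 46% and 78%.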

Compound 4, a percentage reported as activity, at one concentration (the size of the read-out at that concentration, not a potency): 55.5%
Estimate against measurement, compound 4: 6.5 percentage points above; the range from low to high includes it.
By their numbers in this assay, from the lowest: compound 1; then compounds 4, 3 and 2 (each within the scatter of the next, the first and the last beyond it).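

In this assay, among the compounds shown here, fluoro in place of methyl on the aromatic carbon para to a large group gives a number 8.9 percentage points lower from compound 3 to compound 4 (within the scatter), so this change on its own is not resolved, whereas fluoro in place of bromo at that carbon gives a number 13.5 percentage points lower from compound 2 to compound 4 (beyond the scatter), the first step at this position to lie beyond the scatter; methyl remains within the scatter of both halogens, so the three groups fall into no clean order. With the 4-fluorophenyl held constant, the sulfur substituent can now also be read alone: pyrimidin-2-yl in place of 1-phenyl-1H-tetrazol-5-yl gives a number 11.8 percentage points higher from compound 1 to compound 4 (beyond the scatter), a modest step that shows the lower number of compound 1 is tied to that substituent rather than to fluoro alone. No supporting evidence bears on why either step arises.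

Among the compounds shown, the 1-phenyl-1H-tetrazol-5-yl group appears only with the 4-fluorophenyl, so whether its step carries over to the bromo or methyl compounds remains open. Also open, on these data alone, is how chloro, methoxy or an amine at that ring carbon would read, and whether the trend extends beyond one tested concentration.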